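This account rests on a few compounds, and the source may have more. Where it says the series, first, only, none or still open, it means among the compounds named here.

The measured compounds, each with its result in an in vitro functional assay on cells for antagonist activity at B1 bradykinin receptor (Homo sapiens), read by luminescence and calcium flux, with a stated time of 2 h; on this read-out lower numbers stand for stronger inhibition and higher numbers for weaker inhibition:
Compound 1 `Cc1ccc(S(=O)(=O)N2C=CNC(=O)[C@H]2CC(=O)N[C@@H]2CCc3ccccc32)cc1` gives 94.7 nM.
Compound 2 `CC1(C)CNCC[C@@H]1NC(=O)C[C@@H]1C(=O)NC=CN1S(=O)(=O)c1ccc(Cl)c(Cl)c1` gives 0.65 nM.
Compound 3 `Cc1cc(S(=O)(=O)N2C=CNC(=O)[C@H]2CC(=O)N[C@H]2CCNCC2(C)C)c(C)cc1Cl` gives 0.31 nM.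

Compound 3 stands lowest of the three numbers in this assay. Within the data shown here, its nearest neighbour is compound 2, and the one measured step, a 2.1-fold lower number from compound 2 to compound 3 (0.32 log units; beyond the scatter), is a change on the sulfonyl sulfur, beyond the scatter but modest. Compound 1 differs from compound 3 in more than one place, so its much higher value can only be noted, not assigned to a single change.

Compound 4 `Cc1cc(S(=O)(=O)N2C=CNC(=O)[C@H]2CC(=O)N2CCC[C@H](N3CCCC3)C2)c(C)cc1Cl` differs from compound 3 by a group of 11 heavy atoms (9 carbon, 2 nitrogen; one five-membered non-aromatic ring with 1 hetero atom, one six-membered non-aromatic ring with 1 hetero atom) in place of a group of 9 heavy atoms (7 carbon, 2 nitrogen; one six-membered non-aromatic ring with 1 hetero atom), on a carbonyl carbon. Among the measured compounds shown here, no measured step bears on this part of the molecule: the only step on record concerns the aryl group on the sulfonyl sulfur, and nothing shows how the amide side of the core tolerates a change of this kind. The expectation therefore rests on compound 3 alone, with a wide range to reflect that nothing directly comparable is known. Compound 4 is estimated to come in at 2.5 nM, between 0.4 nM and 20 nM, which would mean a step of an 8.1-fold higher number from compound 3 to compound 4 (0.91 log units; beyond the scatter) in this assay, an expected mild rise that may or may not exceed the scatter.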

Compound 4, half-maximal inhibitory concentration: 38 nM
Compound 4: the middle estimate sits 15-fold (1.18 log units) below what was measured; the measured number lies above the stated range.
By their numbers in this assay, from the lowest: compound 3; then compound 2; then compound 4; then compound 1.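

In this assay, among these compounds, the first measured step on the carbonyl carbon is large, a 120-fold higher number from compound 3 to compound 4 (2.09 log units; beyond the scatter), and it far exceeds the modest 2.1-fold lower number from compound 2 to compound 3 (0.32 log units; beyond the scatter), which concerns the sulfonyl sulfur. This shows that the potency of this series depends strongly on the group on the carbonyl carbon, and that keeping a six-membered non-aromatic ring with 1 hetero atom there does not preserve the low number of compound 3, since the entering group also adds a five-membered non-aromatic ring and carries 0 hydrogen-bond donors where the leaving group carried 2. Nothing available accounts for the rise or divides it among these differences.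

The compounds shown leave open whether the rise follows from the added five-membered ring or from the lost hydrogen-bond donors, which a dimethylamino group or a primary amine on the same six-membered ring could help to separate. They also leave open whether the 3,4-dichlorophenyl group on the sulfonyl sulfur would keep its relation to the 4-chloro-2,5-dimethylphenyl group when this new group sits on the carbonyl carbon.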